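This account rests on a few compounds, and the source may have more. Where it says the series, first, only, none or still open, it means among the compounds named here.

Of the compounds shown here, two built on the same core have been tested in a functional assay on SF-295 cells (Homo sapiens) for inhibition, read by sulforhodamine B assay, with a stated time of 48 h, tested at 0.01 uM (on this read-out higher numbers stand for a weaker effect at the one concentration tested and lower numbers for a stronger effect), and a third is about to be. Compound 1 `O=C(Nc1cccc(-n2cc(-c3ccncc3)c(-c3cc(O)cc(Cl)c3)n2)c1)Nc1ccc(Cl)c(C(F)(F)F)c1` carries a 3-chloro-5-hydroxyphenyl group and a trifluoromethyl-bearing urea end; in this assay compound 1 gives 58%. Compound 2 `O=C(Nc1cccc(-n2cc(-c3ccncc3)c(-c3cc(O)cc(Cl)c3)n2)c1)Nc1ccc(Cl)c(Cl)c1` differs only in the urea end, where chloro stands in place of trifluoromethyl, and in this assay compound 2 gives 92%. Going by the values given here, on these two numbers compound 1 stands as the lowest, that is the stronger effect, and the one measured step, a number 34 percentage points higher from compound 1 to compound 2 (beyond the scatter), shows how much this read-out can move with a single small change.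

Compound 3 `COc1cc(Cl)cc(-c2nn(-c3cccc(NC(=O)Nc4ccc(Cl)c(C(F)(F)F)c4)c3)cc2-c2ccncc2)c1` is the next to be measured. It differs from compound 1 by methyl in place of hydrogen on an oxygen on an aromatic ring. Among the compounds with values here, no measured step touches the hydroxy group, so the step from chloro to trifluoromethyl on the other ring does not bear directly on this change, and there is no guide to its direction. Some loss of effect is expected, and for compound 3 a value of 75% is estimated, within 50% to 98%, a step of a number 17 percentage points higher from compound 1 to compound 3 (beyond the scatter).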

Compound 3, a percentage reported as activity, at one concentration (the size of the read-out at that concentration, not a potency): 59%
Compound 3: the middle estimate sits 16 percentage points above what was measured, and the stated range covers the measured number.
By their numbers in this assay, from the lowest: compounds 1 and 3 (each within the scatter of the next); then compound 2.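

In this assay, the step from 3-chloro-5-hydroxyphenyl to 3-chloro-5-methoxyphenyl gives a number 1 percentage points higher from compound 1 to compound 3 (within the scatter), so at this single concentration the two compounds cannot be told apart. Going by these compounds alone, this is the first look at this part of the molecule, and it shows that a methyl can sit on this oxygen without any change in the read-out that rises above the usual scatter, whereas the one earlier step, at the urea end, gave a number 34 percentage points higher from compound 1 to compound 2 (beyond the scatter) and lay beyond it. Nothing available here explains why the hydrogen on this oxygen can be replaced with so little effect on the number.

This result rests on a single pair of compounds at a single concentration, so it cannot show whether the two would also match at other concentrations, or whether the same swap would behave alike on the chloro urea end of compound 2. It also leaves open what happens with an ethoxy group or a longer chain on this oxygen, or with an amine or a carboxylic acid in place of the hydroxy group.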